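The source may hold more compounds than are shown below. What is called first, only, known or untested is meant among the compounds shown, and "the series" means these compounds.

Measured so far in an assay for inhibition of transmembrane protease serine 4 (Homo sapiens), read by fluorescence; on this read-out higher numbers stand for weaker inhibition and lower numbers for stronger inhibition:
- compound 1, `O=C(Nc1cc(C(F)(F)F)cc(C(F)(F)F)c1)c1cc(Br)ccc1O`: 13000 nM
- compound 2, `O=C(Nc1cc(C(F)(F)F)ccc1C(F)(F)F)c1cc(Cl)ccc1O`: 20000 nM

Both numbers are weak inhibition, and the pair stands within the usual scatter of each other: compound 2 and compound 1 cannot be told apart on these two values, so no direction of change is read from them. Among the measured compounds shown here, no step between measured compounds is available, and the two compounds differ in more than one place, so nothing about any single change has been measured yet.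

Compound 3, `O=C(Nc1cccc(C(F)(F)F)c1)c1cc(Cl)ccc1O`, is the next to be measured in this assay. It comes from compound 2 by one change: hydrogen in place of trifluoromethyl on an aromatic carbon. What leaves is the trifluoromethyl that sits ortho to a large group and para to a trifluoromethyl group; a hydrogen atom takes its place.

For the measured compounds named here, with no measured step to lean on, the expectation for the change from compound 2 to compound 3 is small, of a size that would not stand out from the scatter, with a slight lean toward a weaker number: a 1.3-fold higher number from compound 2 to compound 3 (0.10 log units; within the scatter). Compound 3 is thus estimated at 25000 nM in this assay, with a range from 8000 nM to 80000 nM.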

Compound 3, half-maximal inhibitory concentration: 13000 nM
The estimate for compound 3 lay 1.9-fold (0.28 log units) above the measured number, and the stated range covers the measured number.
By their numbers in this assay, from the lowest: compounds 1, 3 and 2 (each within the scatter of the next).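

In this assay, among the compounds shown here, the first step that can be read at this position is a 1.5-fold lower number from compound 2 to compound 3 (0.19 log units; within the scatter), so hydrogen in place of the trifluoromethyl that sits ortho to a large group and para to a trifluoromethyl group cannot be told from no change. With this trifluoromethyl gone, compound 3 gives 13000 nM, so inhibition in this series stays weak and does not depend measurably on this group, at least against hydrogen and within the resolution of this read-out. No available measurement bears on the reason for this result.

At this position, the compounds shown cover only trifluoromethyl and hydrogen, so it remains open whether an amine, a carboxylic acid or a longer chain on the same aromatic carbon would give a step beyond the scatter. Also open, from the compounds shown here alone, is what the remaining trifluoromethyl of compound 3 contributes, and whether any single change to the shared core can move the number away from this weak range.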